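The source may report more compounds than this note shows. Statements on the series, on what has been measured and on what is new or still open speak of the compounds shown alone.

Working notes on the series.

Compound 1 `CNC(=O)C#Cc1ccc(NC(=O)Nc2ccc(Cl)c(C(F)(F)F)c2)cc1` is measured in a functional assay on HT-29 cells (Homo sapiens) for inhibition, read by MTT assay, with a stated time of 120 h (a lower number here means a stronger inhibitor, a higher number a weaker inhibitor), where compound 1 gives 14000 nM, the highest of the three numbers in hand. The two related compounds both carry a 1-phenylethyl on the amide-type nitrogen: compound 2 `CC(NC(=O)c1cccc(-c2ccc(NC(=O)Nc3ccc(Cl)c(C(F)(F)F)c3)cc2)c1)c1ccccc1` gives 6320 nM in this assay, and compound 3 `CC(NC(=O)C#Cc1ccc(NC(=O)Nc2ccc(Cl)c(C(F)(F)F)c2)cc1)c1ccccc1` gives 4920 nM. For the measured compounds named here, the one step that can be read off, a 2.8-fold lower number from compound 1 to compound 3 (0.45 log units; beyond the scatter), concerns the amide substituent and not the linker; compound 2 and compound 3 differ in their linker, and their two values sit within the scatter of each other.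

Compound 4 `CNC(=O)CCc1ccc(NC(=O)Nc2ccc(Cl)c(C(F)(F)F)c2)cc1` is not yet measured. It differs from compound 1 as follows: 2-(methylcarbamoyl)ethyl in place of 2-(methylcarbamoyl)ethynyl on an aromatic carbon. Going by the values given here, no measured step bears directly on this change. Among the compounds with values here, the only comparison touching the linker, compound 2 against compound 3, shows no difference beyond the scatter, so no step beyond the scatter is expected here either, with wide uncertainty in both directions; the expected step is no change at the digits printed from compound 1 to compound 4 (within the scatter). Compound 4 is therefore estimated at 14000 nM in this assay, within a range of 5000 nM to 40000 nM.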

Compound 4, half-maximal inhibitory concentration: 20600 nM
The estimate for compound 4 lay 1.5-fold (0.17 log units) below the measured number, within the range that was stated.
By their numbers in this assay, from the lowest: compounds 3 and 2 (each within the scatter of the next); then compounds 1 and 4 (each within the scatter of the next).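

With a 1.5-fold higher number from compound 1 to compound 4 (0.17 log units; within the scatter) in this assay, 2-(methylcarbamoyl)ethyl can stand in place of 2-(methylcarbamoyl)ethynyl on this aromatic carbon without a step beyond the scatter. For the compounds shown here, this is the first direct reading of this position, with the methyl on the amide nitrogen and the rest of the core of compound 1 held fixed, and the loss of the triple bond leaves the number within the scatter. No measurement at hand accounts for this result.

It remains open whether the same holds with 1-phenylethyl on the amide nitrogen, as the saturated counterpart of compound 3 is not among the compounds shown. Also open, from the compounds shown here alone, is how this position responds to a longer chain, or to a carboxylic acid or an amine in place of the methylcarbamoyl end.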